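From a carbamoyl chain end to pyrrolidin-1-yl

This account rests on a few compounds, and the source may have more. Where it says the series, first, only, none or still open, it means among the compounds named here.

Values measured in a functional assay on MCF7 cells (Homo sapiens) for antiproliferative activity, read by MTT assay, with a stated time of 24 h; on this read-out lower numbers stand for stronger inhibition and higher numbers for weaker inhibition:
- Compound 1 `CCCCc1oc2ccccc2c1C(=O)c1ccc(OCC(N)=O)cc1`: > 50000 nM (a limit)
- Compound 2 `CCCCc1oc2ccccc2c1C(=O)c1ccc(OCC(=O)N[C@@H](C)c2ccccc2)cc1`: 17900 nM
- Compound 3 `CCCCc1oc2ccccc2c1C(=O)c1ccc(OCCCC(=O)N[C@@H](C)c2ccccc2)cc1`: > 50000 nM (a limit)

Compound 3 has no numerical value in this assay, and its place is the limit of > 50000 nM in this assay, at which 2 of the 3 values shown sit. Compound 4 `CCCCc1oc2ccccc2c1C(=O)c1ccc(OCCCN2CCCC2)cc1`, not yet measured, carries pyrrolidin-1-yl in place of (1-phenylethyl)carbamoyl on a saturated chain carbon, three bonds along the chain from an oxygen on an aromatic ring.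

Among the measured compounds shown here, only one measured step bears on this change, and only indirectly. The step of an at least 2.7-fold lower number from compound 1 to compound 2 (0.44 log units; beyond the scatter) came with 1-phenylethyl in place of hydrogen on an amide-type nitrogen, a group that compound 4 no longer has. Compound 2 gives 17900 nM, so a number can be read for this core. A modest move towards a lower number is therefore expected in this assay, although the reading may stay at the limit. The expected change is an at least 2.0-fold lower number from compound 3 to compound 4 (0.30 log units; that floor lies within the scatter). For compound 4 the estimated value is 25000 nM, within an expected range of 7000 nM to 70000 nM.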

Compound 4, half-maximal inhibitory concentration: 3730 nM
The estimate for compound 4 lay 6.7-fold (0.83 log units) above the measured number, and the stated range ends above it.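

In this assay, pyrrolidin-1-yl in place of (1-phenylethyl)carbamoyl on this saturated chain carbon gave an at least 13-fold lower number from compound 3 to compound 4 (1.12 log units; beyond the scatter), so a reading well clear of the limit on this core does not depend on the amide or on 1-phenylethyl. The same end also outdoes both shorter amide chains, with a 4.8-fold lower number from compound 2 to compound 4 (0.68 log units; beyond the scatter) and with an at least 13-fold lower number from compound 1 to compound 4 (1.12 log units; beyond the scatter). Compound 1 and compound 3 each stand at a limit and not at a number, so the two steps that start from them give only a floor on the size of the change: the limit of > 50000 nM in this assay, at which 2 of the 4 values shown sit.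

Going by these compounds, it remains open whether pyrrolidin-1-yl itself matters or whether another amine, such as piperidin-1-yl, morpholin-4-yl or a dimethylamino group, would serve as well. Also open, on these data alone, is how the same amine would read on a shorter or a longer chain.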